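Trading 2-chlorothiophen-3-yl for 2-carboxyethyl in compound 4

This account rests on a few compounds, and the source may have more. Where it says the series, first, only, none or still open, it means among the compounds named here.

Of the compounds shown here, three sharing one core have been measured in a functional assay on the whole organism (strain Wistar) for inhibition, with Rattus norvegicus as the target, read by paw edema, with stated times of 30 min and 2 h, at a dose of 20 mg/kg; a lower number here means less inhibition, a higher number more inhibition at the dose given (going by the name of the read-out). Compound 1 `CCOC(=O)C1=C(C)NC(C)=C(C(=O)OCC)C1c1ccc(OCC(=O)NNC(=O)c2ccc(C)cc2)cc1` gives 46.7%, compound 2 `CCOC(=O)C1=C(C)NC(C)=C(C(=O)OCC)C1c1ccc(OCC(=O)NNC(=O)c2cccs2)cc1` gives 62.2%, and compound 3 `CCOC(=O)C1=C(C)NC(C)=C(C(=O)OCC)C1c1ccc(OCC(=O)NNC(=O)c2ccsc2Cl)cc1` gives 52.8%. Compound 3 stands second highest of the three numbers: its nearest neighbour is compound 1, and the two differ only within the scatter, while compound 2 lies higher, again within the scatter. For the measured compounds named here, the one step that went beyond the scatter was a number 15.5 percentage points higher from compound 1 to compound 2 (beyond the scatter); the other two, a number 6.1 percentage points higher from compound 1 to compound 3 (within the scatter) and a number 9.4 percentage points lower from compound 2 to compound 3 (within the scatter), stayed inside it.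

Compound 4 `CCOC(=O)C1=C(C)NC(C)=C(C(=O)OCC)C1c1ccc(OCC(=O)NNC(=O)CCC(=O)O)cc1` differs from compound 3 at the same carbonyl carbon that all three measured steps touched: 2-carboxyethyl in place of 2-chlorothiophen-3-yl on a carbonyl carbon. Going by the values given here, every measured step so far exchanged one aromatic ring for another on that carbon, and the largest of them was modest. Among the compounds with values here, no measured step shows what an open chain carrying a carboxylic acid does there, so the safest expectation is a change no larger than the scatter, with a wide range to cover the unknown. Compound 4 is therefore estimated at 50%, with a range from 33% to 67%. That estimate means an expected step of a number 2.8 percentage points lower from compound 3 to compound 4 (within the scatter).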

Compound 4, a percentage reported as inhibition, in the whole organism at one dose (the size of the read-out at that dose, not a potency): 57.8%
Compound 4: middle estimate off by 7.8 percentage points, on the low side, within the range that was stated.
By their numbers in this assay, from the lowest: compounds 1, 3, 4 and 2 (each within the scatter of the next, the first and the last beyond it).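

In this assay, 2-carboxyethyl on the carbonyl carbon whose other neighbour is the amide-type nitrogen gives a number 5 percentage points higher from compound 3 to compound 4 (within the scatter) and a number 4.4 percentage points lower from compound 2 to compound 4 (within the scatter) against the two thiophene-based groups, so at this position an open chain with no ring cannot be told apart from 2-chlorothiophen-3-yl or thiophen-2-yl. Against 4-methylphenyl the same chain gives a number 11.1 percentage points higher from compound 1 to compound 4 (beyond the scatter) in this read-out, which makes compound 4 the second compound, after compound 2, to stand clear of compound 1, while compound 3 goes against this trend by staying within the scatter of compound 1. Among these four compounds, then, an aromatic ring on this carbon is not required for the level of inhibition seen, though nothing at hand explains why the chain behaves as it does.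

From the compounds shown here alone, what remains open is whether the carboxylic acid or the chain itself accounts for this result, a question that a plain propyl chain or the ethyl ester of the same acid could address. Equally open, going by these compounds, is how a longer chain ending in the acid, or a chain ending in a primary amine, would read at this position.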